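This account rests on a few compounds, and the source may have more. Where it says the series, first, only, none or still open, it means among the compounds named here.

Compound 1 `CC(C)OC(=O)N1CCC(n2ncc3cc(-c4ccc(S(C)(=O)=O)cc4)ncc32)CC1` — in a functional assay on HEK293 cells for agonist activity at Glucose-dependent insulinotropic receptor (Homo sapiens), read by cAMP accumulation, with a stated time of 30 min (on this read-out lower numbers stand for an effect already at smaller amounts and higher numbers for an effect only at larger amounts of compound), compound 1 gives 42 nM.
Compound 2 `CC(C)OC(=O)N1CCC(n2ncc3cc(-c4cc(F)c(C(=O)N(C)C)cc4F)ncc32)CC1` — in this assay compound 2 gives 46 nM.

Of the compounds shown here, two built on one shared core have been measured so far, differing in the aryl group borne on that core. In this assay compound 2 and compound 1 sit within the scatter of each other, so neither can be set apart from the other on the numbers at hand; compound 2 simply stands alongside compound 1.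

Compound 3 `CCCNC(=O)c1cc(F)c(-c2cc3cnn(C4CCN(C(=O)OC(C)C)CC4)c3cn2)cc1F` is the untested member. It differs from compound 2 in one place: propylamino in place of dimethylamino on a carbonyl carbon. Within the data shown here, no step between two measured compounds separates a tertiary amide from a secondary one, so the data give no direct guide to the size of this change. Because compound 1 gives 42 nM and compound 2 gives 46 nM in this assay despite quite different aryl groups, only a small step is expected here, not beyond the scatter, in either direction. For compound 3 the estimate in this assay is 60 nM, with a range from 20 nM to 200 nM. That corresponds to an expected step of a 1.3-fold higher number from compound 2 to compound 3 (0.12 log units; within the scatter).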

Compound 3, half-maximal effective concentration: 14 nM
Compound 3: middle estimate off by 4.3-fold (0.63 log units), on the high side, outside the stated range (below it).
By their numbers in this assay, from the lowest: compound 3; then compounds 1 and 2 (each within the scatter of the next).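

Among these compounds, at this place, on a carbonyl carbon whose other neighbour is an aromatic carbon, the amide group proves able to move the number: in this assay propylamino in place of dimethylamino gives a 3.3-fold lower number from compound 2 to compound 3 (0.52 log units; beyond the scatter) and thus a first measured step at this position. The earlier compounds shown here could not show this, since compounds 1 and 2 differ in their whole aryl group and sit within the scatter of each other, while this change is confined to the amide nitrogen and its substituents. Two things change together in this one step: the amide hydrogen enters as a hydrogen-bond donor, and the substituents go from dimethylamino with 3 heavy atoms to propylamino with 4, and nothing at hand explains the step.

Open, from the compounds shown here alone, is whether the amide hydrogen or the propyl chain accounts for the step, a question that methylamino, with the hydrogen but a shorter chain, and methyl(propyl)amino, with the chain but no hydrogen, would bear on. Also open, going by these compounds, is how far the trend runs at this place, for instance with a longer chain such as butylamino or with a carboxylic acid in place of the amide.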